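A few compounds are considered here, and "the series" means these few. Any claim that something is new, unique, unknown or untested is made for them only; others in the source may bear on it.

Measured compounds in an ADME assay on Raji cells (Homo sapiens) for cytotoxicity, read by CellTiter-Glo and resazurin assay, with a stated time of 72 h; a higher number here means that more compound is needed for the effect, a lower number that less compound is needed:

Compound 1, `CC(C)N(Cc1cccc(OCCCCCC(=O)O)c1)C(=O)c1ccc(-c2cccc3ccccc23)cc1`, gives only a limit, > 26000 nM.
Compound 2, `CC(C)N(Cc1cccc(OCCCCCC(=O)O)c1)C(=O)c1ccc(-c2ccncc2)cc1`, gives only a limit, > 26000 nM.
Compound 3, `CC(C)N(Cc1cccc(OCCCCCC(=O)O)c1)C(=O)c1ccc(-c2cccc(-c3ccccc3)c2)cc1`, gives only a limit, > 26000 nM.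

Compound 3 thus stands at the assay limit, as do the two other compounds, so no value places it against them. Compound 4, `CC(C)COc1cccc(-c2ccc(C(=O)N(Cc3cccc(OCCCCCC(=O)O)c3)C(C)C)cc2)c1`, differs from compound 3 by isobutoxy in place of phenyl on an aromatic carbon. The measured steps bearing on this change are all unreadable: a step that the two limits leave unreadable from compound 1 to compound 3, a step that the two limits leave unreadable from compound 2 to compound 3 and a step that the two limits leave unreadable from compound 1 to compound 2, since (the limit of > 26000 nM in this assay, at which 3 of the 3 values shown sit). Going by the values given here, no measured step therefore suggests a readable change in this assay, and compound 4 is expected to remain at that limit, with a step that the limit leaves unreadable from compound 3 to compound 4 no larger than the scatter. The estimate for compound 4 is 35000 nM, ranging from 15000 nM to 150000 nM.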

Compound 4, half-maximal effective concentration: > 26000 nM
Compound 4: no number, only a limit; the forecaster's own chance of this, stated with the estimate: 80%; the middle value does not contradict the limit.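

Compound 4 also gives only a limit in this assay, so its steps from compound 1, compound 2 and compound 3 cannot be read: the limit of > 26000 nM in this assay, at which 4 of the 4 values shown sit.

The compounds shown leave open whether these different groups on the shared core differ at all in this assay.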